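Butyl Carbonate to Glutarate Half-Ester on the Shared Core

The source may hold more compounds than are shown below. What is called first, only, known or untested is meant among the compounds shown, and "the series" means these compounds.

Compound 3 `CCCCOC(=O)OCC1OC(n2cc(C)c(=O)[nH]c2=O)CC1N=[N+]=[N-]` gives the lowest number shown in an ADME assay on the whole organism (serum) with Homo sapiens as the target (a higher number here means that the compound lasts longer, a lower number that the compound disappears faster), at 0.15 h. Compound 2 `Cc1cn(C2CC(N=[N+]=[N-])C(COC(=O)OCCCCO)O2)c(=O)[nH]c1=O` gives 0.5 h. For compound 1 `Cc1cn(C2CC(N=[N+]=[N-])C(COC(=O)NCCCO)O2)c(=O)[nH]c1=O` the result is a limit of the assay, > 48 h. Two measured steps are large, an at least 96-fold lower number from compound 1 to compound 2 (1.98 log units; beyond the scatter) and an at least 320-fold lower number from compound 1 to compound 3 (2.50 log units; beyond the scatter), each exchanging the group on the carbonyl carbon. One is modest: a 3.3-fold lower number from compound 2 to compound 3 (0.52 log units; beyond the scatter). Compound 4 `Cc1cn(C2CC(N=[N+]=[N-])C(COC(=O)CCCC(=O)O)O2)c(=O)[nH]c1=O` differs from compound 3 by 3-carboxypropyl in place of butoxy on a carbonyl carbon. This change again alters what sits on the carbonyl carbon, as in the two large steps, and its carboxy end recalls the hydroxy of the modest step, so a rise is expected, likely beyond the scatter. Compound 4 is estimated at 1 h, with a range from 0.2 h to 5 h, meaning a 6.7-fold higher number from compound 3 to compound 4 (0.82 log units; beyond the scatter).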

Compound 4, half-life: 30 h
For compound 4 the middle estimate is 30-fold (1.48 log units) below the measured one, and the stated range ends below it.
By their numbers in this assay, from the lowest: compound 3; then compound 2; then compound 4. At a limit, above all of these: compound 1.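

In this assay a long life on the shared core no longer rests on the (3-hydroxypropyl)amino of compound 1 alone: 3-carboxypropyl on this carbonyl carbon gives a 200-fold higher number from compound 3 to compound 4 (2.30 log units; beyond the scatter) and, set against 4-hydroxybutoxy, a 60-fold higher number from compound 2 to compound 4 (1.78 log units; beyond the scatter) as well. The remaining step, an at least 1.6-fold lower number from compound 1 to compound 4 (0.20 log units; that floor lies within the scatter), sets no order between these two. The number for compound 1 is a limit: the limit of > 48 h in this assay, at which 1 of the 4 values shown sits.

Still open, on these data alone, is whether the rise goes with the carboxy end or with the loss of the oxygen that butoxy places on the carbonyl carbon. A plain butyl chain at this place, or the methyl ester of the carboxylic acid, would separate the two.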